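This account rests on a few compounds, and the source may have more. Where it says the series, first, only, none or still open, it means among the compounds named here.

Series notes. In a functional assay on MCF7 cells (Homo sapiens) for antiproliferative activity, read by MTT assay, with a stated time of 48 h (on this read-out lower numbers stand for stronger inhibition and higher numbers for weaker inhibition), compound 1 `O=Cc1cn(-c2ccccc2)nc1-c1ccc(Cl)cc1` gives 9650 nM, compound 2 `c1ccc(-c2nn(-c3ccccc3)cc2-c2nc3ccccc3[nH]2)cc1` gives 3190 nM, and compound 3 `Clc1ccc2[nH]c(-c3cn(-c4ccccc4)nc3-c3ccccc3)nc2c1` gives 1960 nM. Compound 2 thus holds the second highest of the three numbers: compound 3 is nearest, a gap within the scatter, while compound 1 is furthest, beyond it. Within the data shown here, the single one-place step so far is a 1.6-fold lower number from compound 2 to compound 3 (0.21 log units; within the scatter). Compound 4 `Brc1ccc2[nH]c(-c3cn(-c4ccccc4)nc3-c3ccccc3)nc2c1` differs from compound 2 by bromo in place of hydrogen on an aromatic carbon. Among the measured compounds shown here, the chloro step from compound 2 to compound 3 is the only comparable change and stayed within the scatter, so in this assay no step beyond the scatter is expected for compound 4 in either direction. The expected step is a 1.6-fold lower number from compound 2 to compound 4 (0.20 log units; within the scatter). Compound 4 is estimated at 2000 nM, within 900 nM to 4500 nM.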

Compound 4, half-maximal inhibitory concentration: 830 nM
Estimate against measurement, compound 4: 2.4-fold (0.38 log units) above; measured number below the stated range.
By their numbers in this assay, from the lowest: compound 4; then compounds 3 and 2 (each within the scatter of the next); then compound 1.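

This aromatic carbon of the fused system can carry a step beyond the scatter: bromo in place of hydrogen gives a 3.8-fold lower number from compound 2 to compound 4 (0.58 log units; beyond the scatter) whereas the chloro step stayed within it. The identity of the halogen also counts here: bromo in place of chloro on the same carbon gives a 2.4-fold lower number from compound 3 to compound 4 (0.37 log units; beyond the scatter) as a separate, directly read step. Nothing on hand explains this difference.

Still open, as far as these compounds go, is whether iodo or fluoro on this carbon would extend the halogen comparison, and whether methoxy or an amine would give a step of similar size. Also open, from the compounds shown here alone, is whether bromo on the other carbons of that ring would behave alike.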